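The compounds below may be only part of what the source reports. "The series", "measured", "known", "first", "only" and "open" are said of these compounds alone.

Working notes on the series, all read in an ADME assay on HCT-116 cells (Homo sapiens) for cytotoxicity, read by CellTiter-Glo, with a stated time of 72 h; on this read-out lower numbers stand for stronger inhibition and higher numbers for weaker inhibition. Compound 1 (`CC1CCN(C2CCN(S(=O)(=O)c3cccnc3)CC2)CC1`) gives > 10000 nM, which is a limit of the assay and not a number. Compound 2 (`Cc1ccc(C2CCN(S(=O)(=O)c3c(C)cc(C)cc3C)CC2)cc1`) gives > 5000 nM, also a limit. Compound 3 (`CC1CCN(C2CCN(S(=O)(=O)c3ccc(-c4ccccc4F)cc3)CC2)CC1`) gives > 5000 nM, again a limit. Compound 3 therefore stands at the limit of > 5000 nM in this assay, at which 2 of the 3 values shown sit. None of the three has a numerical reading, so no measured step can be read between them.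

Compound 4 (`CC1CCN(C2CCN(S(=O)(=O)c3ccc(C(C)C)cc3)CC2)CC1`) departs from compound 3 in one place: isopropyl in place of 2-fluorophenyl on an aromatic carbon. This puts isopropyl in place of 2-fluorophenyl on an aromatic carbon, para to a large group.

The expected step, a step that the limit leaves unreadable from compound 3 to compound 4, is none beyond the scatter in either direction, and another limit is the likeliest report. This expectation rests on compound 3, whose limit is > 5000 nM. The estimate for compound 4 in this assay is 8000 nM, with an expected range of 3000 nM to 20000 nM.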

Compound 4, half-maximal inhibitory concentration: > 5000 nM
Compound 4 ended at the assay's limit (the forecaster's own chance of this, stated with the estimate: 85%); the middle value is on the limit's open side.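

In this assay compound 4 gives > 5000 nM, which is a limit and not a number. Compound 3 also stands at a limit, and no step can be read between compound 3 and compound 4. The compounds shown leave open how isopropyl and 2-fluorophenyl compare on a numerical reading.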